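The source may hold more compounds than are shown below. What is called first, only, known or untested is meant among the compounds shown, and "the series" means these compounds.

Compound 3, `CCOC(=O)CCCCCOc1cccc(CN(C(=O)c2ccc(-c3cccc(OC(F)(F)F)c3)cc2)C(C)C)c1`, is one of three close relatives that share the same core and differ only in the group carried on the outer benzene ring. In an ADME assay on HepG2 cells (Homo sapiens) for cytotoxicity, read by CellTiter-Glo and resazurin assay, with a stated time of 72 h (on this read-out lower numbers stand for an effect already at smaller amounts and higher numbers for an effect only at larger amounts of compound), compound 3 gives > 26000 nM, which is a limit of the assay rather than a measured number. Compound 1, `CCOC(=O)CCCCCOc1cccc(CN(C(=O)c2ccc(-c3cccc(NC(C)=O)c3)cc2)C(C)C)c1`, gives in this assay > 26000 nM, again a limit. Compound 2, `CCOC(=O)CCCCCOc1cccc(CN(C(=O)c2ccc(-c3cccc(-c4nnc(C)o4)c3)cc2)C(C)C)c1`, gives in this assay > 26000 nM, also a limit. The three steps that connect them, a step that the two limits leave unreadable from compound 1 to compound 2, a step that the two limits leave unreadable from compound 1 to compound 3 and a step that the two limits leave unreadable from compound 2 to compound 3, cannot be read in size or direction because of the limit of > 26000 nM in this assay, at which 3 of the 3 values shown sit. So far, then, nothing in this small set has shown any measurable cytotoxicity.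

Compound 4, `CCOC(=O)CCCCCOc1cccc(CN(C(=O)c2ccc(-c3cc(F)cc(OC)c3)cc2)C(C)C)c1`, differs from compound 3 in one place: 3-fluoro-5-methoxyphenyl in place of 3-(trifluoromethoxy)phenyl on an aromatic carbon. The measured steps bear on this change only in a weak sense, since none of them produced a readable effect on cytotoxicity, whatever the group on that ring. The expectation for compound 4 is therefore no step beyond the usual scatter, which in this assay means an expected step that the limit leaves unreadable from compound 3 to compound 4. Compound 4 is expected to give about 30000 nM, with a range from 15000 nM to 80000 nM, and most likely the assay will once more report only a limit.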

Compound 4, half-maximal effective concentration: > 26000 nM
Compound 4: a limit, no number; the forecaster's own chance of this, stated with the estimate: 85%; the middle value does not contradict the limit.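

Compound 4 adds no readable step: its comparisons with compound 1, compound 2 and compound 3 cannot be read in size or direction, because all four results are limits rather than measured numbers: the limit of > 26000 nM in this assay, at which 4 of the 4 values shown sit. The compounds shown leave open at what concentration, if any, each would harm the cells, and whether the outer-ring group matters.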